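Benzyl replacement on the shared amide core: compound 4

A few compounds are considered here, and "the series" means these few. Any claim that something is new, unique, unknown or untested is made for them only; others in the source may bear on it.

Measured in a functional assay on HCT-116 cells (Homo sapiens) for antiproliferative activity, read by MTT assay, with a stated time of 48 h; a lower number here means a stronger inhibitor, a higher number a weaker inhibitor:
Compound 1 `COc1ccc(CN(C(=O)CSc2nc3ccccc3s2)c2cc(OC)c(OC)c(OC)c2)cc1C` gives 17100 nM.
Compound 2 `COc1ccc(CN(C(=O)CSc2nc3cc(Br)ccc3s2)c2cc(OC)c(OC)c(OC)c2)cc1O` gives 3380 nM.
Compound 3 `COc1cc(CN(C(=O)CSc2nc3ccccc3s2)c2cc(OC)c(OC)c(OC)c2)cc(OC)c1OC` gives 65300 nM.

Compound 3 carries the highest number of the three, beyond the scatter from compound 1 and further still from compound 2. Compound 4 `COc1cc(N(Cc2ccc(Cl)cc2)C(=O)CSc2nc3ccccc3s2)cc(OC)c1OC` keeps the shared core and changes only the group on the saturated chain carbon bound to the amide-type nitrogen: 4-chlorophenyl in place of 3,4,5-trimethoxyphenyl on a saturated chain carbon bound to an amide-type nitrogen. Among the measured compounds shown here, one measured step bears on this place: a 3.8-fold higher number from compound 1 to compound 3 (0.58 log units; beyond the scatter), where the 3,4,5-trimethoxyphenyl entered in place of 4-methoxy-3-methylphenyl. Compound 4 takes that 3,4,5-trimethoxyphenyl out again, so a step toward a lower number of comparable size is expected, namely a 4.4-fold lower number from compound 3 to compound 4 (0.64 log units; beyond the scatter). For the measured compounds named here, no single step links compound 2 to either neighbour; its value alone marks the lower end seen so far. For compound 4 the estimated value is 15000 nM, within 5000 nM to 45000 nM.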

Compound 4, half-maximal inhibitory concentration: 603000 nM
Beside the measured number, compound 4's estimate is 40-fold (1.60 log units) below it; measured number above the stated range.
By their numbers in this assay, from the lowest: compound 2; then compound 1; then compound 3; then compound 4.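

In this assay, the group on the saturated chain carbon bound to an amide-type nitrogen carries more weight than the earlier step showed: 4-chlorophenyl gives a 9.2-fold higher number from compound 3 to compound 4 (0.97 log units; beyond the scatter) and a 35-fold higher number from compound 1 to compound 4 (1.55 log units; beyond the scatter). Removing 3,4,5-trimethoxyphenyl therefore does not by itself lower the number, and 4-methoxy-3-methylphenyl in compound 1 gives the lowest number of these three compounds. No available evidence explains this rise. Still open, from the compounds shown here alone, is how a phenyl carrying an amine or a carboxylic acid at this place would compare, and whether this order holds on the core of compound 2.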